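The compounds below may be only part of what the source reports. "The series", "measured", "known", "first", "only" and "open" are said of these compounds alone.

Compound 1 `CNc1nc(OCCCN(C)C)c2sc(-c3ccc(C(F)(F)F)cc3)cc2n1` gives in a physicochemical assay for solubility, at pH 2 (on this read-out higher numbers stand for higher solubility and lower numbers for lower solubility), a value of 174 ug/mL. Compound 2 `CNc1nc(NC(C)(C)C)c2sc(-c3ccc(C(F)(F)F)cc3)cc2n1` gives in this assay a value of 1.6 ug/mL. Compound 3 `CNc1nc(NC2CCOCC2)c2sc(-c3ccc(C(F)(F)F)cc3)cc2n1` is reported in this assay only as a limit, < 5 ug/mL, and not as a number. Compound 3 therefore stands low among the numbers shown, and where it lies beneath that limit is not known (the limit of < 5 ug/mL in this assay, at which 1 of the 3 values shown sits). The step of a 110-fold lower number from compound 1 to compound 2 (2.04 log units; beyond the scatter) and the step of an at least 34-fold lower number from compound 1 to compound 3 (1.54 log units; beyond the scatter) were both large falls when the 3-(dimethylamino)propoxy group gave way to an amino group. The step that the limit leaves unreadable from compound 2 to compound 3 cannot be read because of the limit.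

Compound 4 `CNc1nc(Nc2cccc(C(N)=O)c2)c2sc(-c3ccc(C(F)(F)F)cc3)cc2n1` differs from compound 3 by 3-carbamoylphenyl in place of oxan-4-yl on a nitrogen on an aromatic ring. Among the measured compounds shown here, no measured step bears directly on this change: the step from compound 2 to compound 3 sits on the same nitrogen, but its size is unreadable. Both compounds bearing an amino group at this position, compound 2 and compound 3, sit low, and compound 4 also bears an amino group there, so compound 4 is expected to remain low, with the step that the limit leaves unreadable from compound 3 to compound 4 expected to be small or none beyond the scatter. Compound 4 is therefore estimated at 3 ug/mL, in a range from 0.5 ug/mL to 15 ug/mL.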

Compound 4, solubility: 85 ug/mL
For compound 4 the middle estimate is 28-fold (1.45 log units) below the measured one; measured number outside the range, above it.
By their numbers in this assay, from the lowest: compound 2; then compound 4; then compound 1.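

On the nitrogen on an aromatic ring, the amino link does not by itself hold the read-out low in this assay: 3-carbamoylphenyl in place of oxan-4-yl gives an at least 17-fold higher number from compound 3 to compound 4 (1.23 log units; beyond the scatter), and 3-carbamoylphenyl in place of tert-butyl gives a 53-fold higher number from compound 2 to compound 4 (1.73 log units; beyond the scatter). The fall that came with losing the 3-(dimethylamino)propoxy group in compound 2 and compound 3 therefore does not hold for every amino group, as (3-carbamoylphenyl)amino on the same aromatic carbon leaves only a 2.0-fold lower number from compound 1 to compound 4 (0.31 log units; beyond the scatter), a modest step though still beyond the scatter. The first of these steps has a floor and no exact size, as compound 3 is known only as a limit and not as a number: the limit of < 5 ug/mL in this assay, at which 1 of the 4 values shown sits.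

The compounds shown do not separate the phenyl ring from the carbamoyl group: a plain phenyl on this nitrogen, or a nitrile or a carboxylic acid in place of the carbamoyl group, would be needed to tell them apart. Also open, as far as these compounds go, is how a longer chain ending in an amine, set on this same nitrogen, would read in this assay.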